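The source may hold more compounds than are shown below. What is called first, only, known or untested is meant among the compounds shown, and "the series" means these compounds.

The compounds here share one core and differ only in the group carried on a saturated chain carbon bound to a double-bonded ring carbon. Compound 1 `COC(=O)C1=C(CN2CC3CC2CO3)NC(c2nccs2)=NC1(C)c1ccc(F)cc1` carries a group of 7 heavy atoms with 2 five-membered non-aromatic rings there, and in a physicochemical assay for solubility, read by HPLC, in phosphate buffer, at pH 6.5 (on this read-out higher numbers stand for higher solubility and lower numbers for lower solubility), compound 1 gives 564 ug/mL. Compound 3 `COC(=O)C1=C(Cn2ccnc2)NC(c2nccs2)=NC1(C)c1ccc(F)cc1` carries 1H-imidazol-1-yl instead, and in this assay compound 3 gives 338 ug/mL; the difference, a 1.7-fold lower number from compound 1 to compound 3 (0.22 log units; within the scatter), lies within the usual scatter, so these two sit together. Compound 2 `COC(=O)C1=C(CN2CCC(F)(F)CC2)NC(c2nccs2)=NC1(C)c1ccc(F)cc1` carries 4,4-difluoropiperidin-1-yl, and in this assay compound 2 gives only a limit, < 1 ug/mL, which is the limit of < 1 ug/mL in this assay, at which 1 of the 3 values shown sits. The step of an at least 560-fold lower number from compound 1 to compound 2 (2.75 log units; beyond the scatter) is the one large movement seen so far, and the only one that reaches a limit.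

Compound 4 `COC(=O)C1=C(COCC(F)(F)F)NC(c2nccs2)=NC1(C)c1ccc(F)cc1` has not yet been measured. It differs from compound 1 in that (a group of 6 heavy atoms (2 carbon, 1 oxygen, 3 fluorine; no ring) in place of a group of 7 heavy atoms (5 carbon, 1 nitrogen, 1 oxygen; 2 five-membered non-aromatic rings with 1 hetero atom each), on a saturated chain carbon bound to a double-bonded ring carbon). The two measured steps from compound 1 show that swapping this group can leave the number unchanged, as with compound 3, or collapse it to a limit, as with compound 2. The entering 2,2,2-trifluoroethoxy group has no ring and no nitrogen, which sets it apart from the imidazole of compound 3. Compound 4 is therefore expected to give about 3 ug/mL, within 0.5 ug/mL to 30 ug/mL. The expected step is a 190-fold lower number from compound 1 to compound 4 (2.27 log units; beyond the scatter).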

Compound 4, solubility: 19 ug/mL
Beside the measured number, compound 4's estimate is 6.3-fold (0.80 log units) below it; low and high end bracket the measured number.
By their numbers in this assay, from the lowest: compound 4; then compounds 3 and 1 (each within the scatter of the next). At a limit, below all of these: compound 2.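

In this assay, this place on a saturated chain carbon bound to a double-bonded ring carbon now shows an intermediate reading as well as the high readings and the limit seen earlier: a 30-fold lower number from compound 1 to compound 4 (1.47 log units; beyond the scatter), and an 18-fold lower number from compound 3 to compound 4 (1.25 log units; beyond the scatter), yet the 2,2,2-trifluoroethoxy group does not drop to the limit. The remaining comparison, an at least 19-fold higher number from compound 2 to compound 4 (1.27 log units; beyond the scatter), starts from a limit and not from a number, so it sets only a minimum size for that gap: the limit of < 1 ug/mL in this assay, at which 1 of the 4 values shown sits. Among these four compounds, the two groups with fluorine, in compound 2 and compound 4, give the two lowest readings, whereas nitrogen in the group does not sort them, as compound 2 has nitrogen and compound 4 has none.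

The compounds shown leave open whether fluorine itself goes with the lower readings, as the fluorine-bearing groups also differ from the others in other ways. A plain ethoxy group or an unsubstituted piperidin-1-yl group at this place would give the direct one-change comparisons with compound 4 and compound 2.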